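The source may hold more compounds than are shown below. What is called first, only, known or untested is meant among the compounds shown, and "the series" means these compounds.

Series notes. Among the compounds with values here, compound 3 `O=C1c2ccc(C#Cc3ccccn3)nc2CCN1C1CCCCC1` carries the lowest number so far in an assay on HEK293 cells for displacement of a labelled ligand from metabotropic glutamate receptor 5 (Homo sapiens), with a stated time of 2 h (a higher number here means a weaker inhibitor, a lower number a stronger inhibitor), where compound 3 gives 2240 nM, though only compound 2 is separated from it beyond the scatter. Compound 1 `O=C1c2ccc(C#Cc3cccs3)nc2CCN1C1CCCC1` gives 2840 nM in this assay, and compound 2 `O=C1c2ccc(C#Cc3cccc(Cl)c3)nc2CCN1C1CCCCC1` gives 12000 nM. Within the data shown here, the one single-point step measured so far is a 5.4-fold lower number from compound 2 to compound 3 (0.73 log units; beyond the scatter). Compound 4 `O=C1c2ccc(C#Cc3cccs3)nc2CCN1C1CCCCC1` is not yet measured; it differs from compound 3 by thiophen-2-yl in place of pyridin-2-yl on a triple-bonded carbon. Among the measured compounds shown here, no measured step covers this exchange directly. Compound 1 carries the same thiophen-2-yl group on the triple-bonded carbon but differs from compound 3 elsewhere in the core, and its value in this assay lies within the scatter of that of compound 3. Compound 4 is therefore expected to show a 1.3-fold higher number from compound 3 to compound 4 (0.13 log units; within the scatter), nothing beyond the scatter, with an estimated value of 3000 nM (range 1200 nM to 8000 nM).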

Compound 4, inhibition constant: 720 nM
For compound 4 the middle estimate is 4.2-fold (0.62 log units) above the measured one; measured number below the stated range.
By their numbers in this assay, from the lowest: compound 4; then compounds 3 and 1 (each within the scatter of the next); then compound 2.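

On the triple-bonded carbon, a 3.1-fold lower number from compound 3 to compound 4 (0.49 log units; beyond the scatter) in this assay separates thiophen-2-yl from pyridin-2-yl, and a 17-fold lower number from compound 2 to compound 4 (1.22 log units; beyond the scatter) separates it further from 3-chlorophenyl. With thiophen-2-yl held constant, cyclohexyl in place of cyclopentyl on the amide-type nitrogen gives a 3.9-fold lower number from compound 1 to compound 4 (0.60 log units; beyond the scatter), so this second position also moves the number. No evidence at hand explains either change.

Still open, as far as these compounds go, is how a methyl group or chlorine on the thiophen-2-yl ring would read. From the compounds shown here alone, a longer chain or a tetrahydropyranyl group in place of cyclohexyl also remains open.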